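Capping the oxygen of compound 2

The compounds below may be only part of what the source reports. "The series", "measured", "known", "first", "only" and "open" are said of these compounds alone.

Compound 1 `O=C(Nc1cccnc1)Oc1ccc(OCc2ccccn2)c(C2(c3ccccc3)CC3CCC2C3)c1`: > 3000 nM
Compound 2 `Oc1ccc(OCc2ccc3ccccc3n2)cc1C1(c2ccccc2)CCCC1`: 1920 nM

Among the compounds with values here, in a functional assay on blood (Homo sapiens) for inhibition (a lower number here means a stronger inhibitor, a higher number a weaker inhibitor), compound 2 gives 1920 nM, the only true number available so far. Compound 1 reads > 3000 nM, which is a limit of the assay and not a number. That leaves compound 2 without a measured neighbour to be compared with step by step.

Compound 3 `C1=CC(COc2ccc(OCc3ccc4ccccc4n3)cc2C2(c3ccccc3)CCCC2)=CNC1` is compound 2 with one change: a group of 7 heavy atoms (6 carbon, 1 nitrogen; one six-membered non-aromatic ring with 1 hetero atom) in place of a hydrogen atom, on an oxygen on an aromatic ring. A hydrogen atom on an oxygen on an aromatic ring gives way to a larger group that holds a six-membered non-aromatic ring.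

Within the data shown here, no measured step shows what such a change does in this assay, so neither direction is favoured, and the expectation stays close to the starting value. The expected step is a 1.0-fold higher number from compound 2 to compound 3 (0.02 log units; within the scatter), and nothing beyond the scatter is foreseen, though the uncertainty is wide. For compound 3 the estimated value is 2000 nM, with an expected range from 500 nM to 8000 nM.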

Compound 3, half-maximal inhibitory concentration: 200 nM
Beside the measured number, compound 3's estimate is 10-fold (1.00 log units) above it, and the stated range ends above it.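

Replacing the hydrogen atom on an oxygen on an aromatic ring with a group that holds a six-membered non-aromatic ring gives, in this assay, a 9.6-fold lower number from compound 2 to compound 3 (0.98 log units; beyond the scatter). The free hydrogen on this oxygen is therefore not needed for inhibition in this series, and the position accepts a much larger group while the number falls in this assay. Nothing measured here accounts for the size of this step.

Within the data shown here, with only one capped compound, it remains open whether the gain comes from this particular ring or from capping the oxygen at all. A small methyl group, a longer carbon chain, an amine or a carboxylic acid on the same oxygen would help to separate these two readings.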